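Cyclohexyl replaces cyclopropylmethyl on the aromatic nitrogen

The source may hold more compounds than are shown below. What is called first, only, known or untested is meant among the compounds shown, and "the series" means these compounds.

Measured compounds:
compound 1, `Cn1c(=O)c(S(=O)(=O)Cc2ccc(F)cc2)cc2cnc(Nc3ccc4[nH]ccc4c3)nc21`, 30000 nM
compound 2, `O=c1c(S(=O)(=O)c2ccc(F)cc2F)cc2cnc(Nc3ccc4[nH]ccc4c3)nc2n1CC1CC1`, 1000 nM

Of the compounds shown here, two have been measured in a functional assay on DU-145 cells (Homo sapiens) for inhibition, read by trypan blue exclusion, with a stated time of 72 h; a lower number here means a stronger inhibitor, a higher number a weaker inhibitor. Compound 1 `Cn1c(=O)c(S(=O)(=O)Cc2ccc(F)cc2)cc2cnc(Nc3ccc4[nH]ccc4c3)nc21` gives 30000 nM, while compound 2 `O=c1c(S(=O)(=O)c2ccc(F)cc2F)cc2cnc(Nc3ccc4[nH]ccc4c3)nc2n1CC1CC1` gives 1000 nM. Compound 2 stands lowest of the two numbers, and its nearest neighbour, compound 1, sits far above it, well beyond the scatter. Among the measured compounds shown here, no direct single-place step between these two is tabulated, so only their two values speak.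

Compound 3 `O=c1c(S(=O)(=O)c2ccc(F)cc2F)cc2cnc(Nc3ccc4[nH]ccc4c3)nc2n1C1CCCCC1` is the next compound to be measured. It differs from compound 2 in one place: cyclohexyl in place of cyclopropylmethyl on an aromatic nitrogen. For the measured compounds named here, both the leaving and the entering group are carbon-only rings without donors or acceptors, and nothing among the measured compounds shows how this position responds. The step from compound 2 to compound 3 in this assay is therefore expected to be small, a 1.2-fold higher number from compound 2 to compound 3 (0.08 log units; within the scatter), with no clear direction beyond the scatter. Compound 3 is estimated at 1200 nM, within a range of 400 nM to 4000 nM.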

Compound 3, half-maximal inhibitory concentration: 10000 nM
For compound 3 the middle estimate is 8.3-fold (0.92 log units) below the measured one; the measured number lies above the stated range.
By their numbers in this assay, from the lowest: compound 2; then compound 3; then compound 1.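

The substituent on the aromatic nitrogen proved to matter: in this assay, the exchange of cyclopropylmethyl for cyclohexyl gives a 10-fold higher number from compound 2 to compound 3 (1.00 log units; beyond the scatter), a step beyond the scatter. Neither group has hydrogen-bond donors or acceptors, and both are carbon-only rings, so a change confined to an all-carbon substituent at this position was enough to separate the two compounds. No measurement shown explains the loss.

Among the compounds shown here, with only this one step at the position, it remains open whether the result follows from the ring, from the carbon linking it to the nitrogen, or from something else. From the compounds shown here alone, how a cyclopentyl group, a longer chain such as n-butyl, or a chain ending in an amine or a carboxylic acid would behave on this nitrogen also remains unknown.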